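The source may hold more compounds than are shown below. What is called first, only, known or untested is meant among the compounds shown, and "the series" means these compounds.

Compound 3 `Cc1ccc(S(=O)(=O)N(C)c2ccc3[nH]c(-c4n[nH]c5ccccc45)cc3n2)cc1` gives 13300 nM in a functional assay on HCT-116 cells (Homo sapiens) for antiproliferative activity, read by MTT assay, with a stated time of 72 h; a higher number here means a weaker inhibitor, a lower number a stronger inhibitor. Among the three measured compounds it stands second highest: compound 2 `CN(C(=O)c1ccco1)c1ccc2[nH]c(-c3n[nH]c4ccccc34)cc2n1` gives 30000 nM, and the step of a 2.3-fold lower number from compound 2 to compound 3 (0.35 log units; beyond the scatter) lies beyond the scatter, while compound 1 `CN(C(=O)c1ccc(Cl)cc1)c1ccc2[nH]c(-c3n[nH]c4ccccc34)cc2n1` gives 3000 nM, so that a 4.4-fold higher number from compound 1 to compound 3 (0.65 log units; beyond the scatter). The remaining measured step, a 10-fold higher number from compound 1 to compound 2 (1.00 log units; beyond the scatter), changes the group on the carbonyl carbon rather than the nitrogen.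

Compound 4 `CN(C(=O)Nc1ccccc1)c1ccc2[nH]c(-c3n[nH]c4ccccc34)cc2n1` differs from compound 3 in one place: phenylcarbamoyl in place of (4-methylphenyl)sulfonyl on a nitrogen on an aromatic ring. Among the compounds with values here, the steps that bear on this change are those that also exchange the group on that nitrogen, namely the two above, which show the aryl carbonyl of compound 1 giving the lowest number and the sulfonyl of compound 3 a number between those of compound 1 and compound 2. The phenylcarbamoyl group shares a carbonyl and a six-membered aromatic ring with the group of compound 1, so a modest move toward lower numbers is expected, though smaller than the step from compound 3 to compound 1, since no urea has yet been measured in this set. For compound 4 the expected step is a 2.7-fold lower number from compound 3 to compound 4 (0.42 log units; beyond the scatter). Compound 4 is therefore estimated at 5000 nM, within the range 1500 nM to 20000 nM.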

Compound 4, half-maximal inhibitory concentration: 1.3 nM
The estimate for compound 4 lay 3800-fold (3.59 log units) above the measured number; measured number below the stated range.
By their numbers in this assay, from the lowest: compound 4; then compound 1; then compound 3; then compound 2.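

In this assay, within the data shown here, the group on the nitrogen on an aromatic ring turns out to matter far more than the earlier compounds suggested: phenylcarbamoyl in place of (4-methylphenyl)sulfonyl gives a 10000-fold lower number from compound 3 to compound 4 (4.01 log units; beyond the scatter), whereas every earlier exchange at this place was modest. On the carbonyl carbon, anilino in place of furan-2-yl gives a 23000-fold lower number from compound 2 to compound 4 (4.36 log units; beyond the scatter), and anilino in place of 4-chlorophenyl gives a 2300-fold lower number from compound 1 to compound 4 (3.36 log units; beyond the scatter); compound 1, compound 3 and compound 4 each carry a six-membered aromatic ring of carbon only, so the presence of such a ring does not by itself separate compound 4 from the other two. No measurement at hand explains the size of this gain.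

The compounds shown leave open whether the hydrogen on the anilino nitrogen matters, a question that an N-methylanilino group on the same carbonyl carbon would address. They also leave open whether the result is tied to the phenyl ring of compound 4 or would hold with a chloro or methoxy group on that ring, or with a benzylamino or cyclohexylamino group in place of anilino.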